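Trifluoromethoxy in place of trifluoromethyl: cytotoxicity notes

The compounds below may be only part of what the source reports. "The series", "measured", "known", "first", "only" and "open" are said of these compounds alone.

Compound 1 `FC(F)(F)c1ccc(Nc2cc(-c3ccncc3)ncn2)cc1` is the starting point of this step. In an ADME assay on BaF3 cells (Mus musculus) for cytotoxicity (on this read-out lower numbers stand for an effect already at smaller amounts and higher numbers for an effect only at larger amounts of compound), compound 1 gives only a limit of the assay, > 10000 nM. The two other measured members of the series stand no differently. Compound 2 `NC(=O)c1cccc(Nc2cc(Nc3ccc(OC(F)(F)F)cc3)ncn2)c1` in this assay gives a limit, > 10000 nM. Compound 3 `NC(=O)CCn1ccc2c(Nc3ccc(OC(F)(F)F)cc3)ncnc21` in this assay likewise gives a limit, > 10000 nM. For the measured compounds named here, every value measured so far therefore sits at the limit of > 10000 nM in this assay, at which 3 of the 3 values shown sit, and no step between measured compounds can be read off, so no size or direction of change has yet been observed.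

Compound 4 `FC(F)(F)Oc1ccc(Nc2cc(-c3ccncc3)ncn2)cc1` remains to be measured. Compared with compound 1 the change is trifluoromethoxy in place of trifluoromethyl on an aromatic carbon. With all three measured values sitting at the limit of > 10000 nM in this assay, at which 3 of the 3 values shown sit, the step from compound 1 to compound 4 is expected to be a step that the limit leaves unreadable from compound 1 to compound 4, that is, nothing beyond the usual scatter. Compound 4 is expected to give about 15000 nM in this assay, within a range of 5000 nM to 50000 nM, and most probably the result will again be reported only as a limit rather than as a number.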

Compound 4, half-maximal effective concentration: > 10000 nM
Compound 4: only a limit was reported; the forecaster's own chance of this, stated with the estimate: 85%; the middle value does not contradict the limit.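

Compound 4, like compound 1, gives only a limit in this assay, so no step can be read for trifluoromethoxy in place of trifluoromethyl: the limit of > 10000 nM in this assay, at which 4 of the 4 values shown sit.

The compounds shown leave open where the half-maximal effective concentration of any of them lies, and whether this change on the shared core alters it at all.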